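A few compounds are considered here, and "the series" means these few. Any claim that something is new, unique, unknown or untested is made for them only; others in the source may bear on it.

Measured so far in this series:
- compound 1, `CCCN(CCC)S(=O)(=O)c1ccc(S(=O)(=O)N2CCC[C@@H](C(=O)OCC)C2)cc1`: > 10000 nM
- compound 2, `CCN(CC)S(=O)(=O)c1ccc(S(=O)(=O)N2CCC[C@@H](C(=O)N3CCN(c4nc(C(F)(F)F)no4)CC3)C2)cc1`: > 10000 nM
- compound 3, `CCN(CC)S(=O)(=O)c1ccc(S(=O)(=O)N2CCC[C@@H](C(=O)NC3COC3)C2)cc1`: > 10000 nM

In a functional assay on MIA PaCa-2 cells (Homo sapiens) for inhibition, read by MTT assay, with a stated time of 3 days (a higher number here means a weaker inhibitor, a lower number a stronger inhibitor), compound 1 gives > 10000 nM, which is a limit of the assay and not a number. Compound 2 gives > 10000 nM in this assay, likewise a limit. Compound 3 gives > 10000 nM in this assay, again a limit. Compound 1 therefore stands nowhere in particular on the numbers shown: it shares (the limit of > 10000 nM in this assay, at which 3 of the 3 values shown sit). Going by the values given here, no step between two measured compounds that differ in a single place is available, so no measured step can guide the next change.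

The compound not yet measured is compound 4, `CCOC(=O)[C@@H]1CCCN(S(=O)(=O)c2ccc(S(=O)(=O)N3CCCCC3)cc2)C1`. Relative to compound 1 the change is piperidin-1-yl in place of dipropylamino on a sulfonyl sulfur. Nothing in the three values gives a direction for this change, and all three sit at the limit. The expected step in this assay is a step that the limit leaves unreadable from compound 1 to compound 4, that is, none beyond the usual scatter, with compound 4 most likely reported as a limit once more. Compound 4 is accordingly estimated at 15000 nM in this assay, within a range of 5000 nM to 50000 nM.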

Compound 4, half-maximal inhibitory concentration: > 10000 nM
Compound 4 was reported as a limit; the forecaster's own chance of this, stated with the estimate: 80%; the middle value is on the limit's open side.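

In this assay compound 1 and compound 4 are both reported as limits, so no new step can be read for piperidin-1-yl in place of dipropylamino on a sulfonyl sulfur. The compounds shown leave open which change, if any, would give a number in this assay rather than a limit: the limit of > 10000 nM in this assay, at which 4 of the 4 values shown sit.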